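From phenyl to 4-chlorophenyl in compound 3

A few compounds are considered here, and "the series" means these few. Any claim that something is new, unique, unknown or untested is made for them only; others in the source may bear on it.

Values so far in a functional assay on SF-539 cells (Homo sapiens) for inhibition, with a stated time of 48 h (on this read-out lower numbers stand for stronger inhibition of growth and higher numbers for weaker inhibition of growth), are these:
compound 1 `COc1ccccc1/C=C/C(=O)c1c(O)cc2occc2c1OC` with 24300 nM
compound 2 `C=CCc1c(O)c(C(=O)/C=C/c2ccccc2)c(OC)c2ccoc12` with 1710 nM

Compound 2 holds the lower of the two numbers in this assay and its gap to compound 1 lies beyond the scatter. The two compounds differ in more than one place, so no single change has been measured. Compound 3 `C=CCc1c(O)c(C(=O)/C=C/c2ccc(Cl)cc2)c(OC)c2ccoc12` departs from compound 2 by one change, chloro in place of hydrogen on an aromatic carbon in all: chloro in place of hydrogen on an aromatic carbon, para to a large group, phenyl to 4-chlorophenyl. Going by the values given here, the expectation starts from compound 2 at 1710 nM and no measured compound carries this change. The step of a 1.1-fold lower number from compound 2 to compound 3 (0.03 log units; within the scatter) is expected to stay within the scatter. The estimated value for compound 3 is 1600 nM with an expected range from 600 nM to 4000 nM on this read-out.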

Compound 3, concentration for 50% growth inhibition: 1790 nM
For compound 3 the middle estimate is 1.1-fold (0.05 log units) below the measured one; low and high end bracket the measured number.
By their numbers in this assay, from the lowest: compounds 2 and 3 (each within the scatter of the next); then compound 1.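

Phenyl to 4-chlorophenyl is the first single change measured in this series, and in this assay it reads as a 1.0-fold higher number from compound 2 to compound 3 (0.02 log units; within the scatter). The earlier compounds shown here differed in more than one place and could not isolate any position, whereas this pair shows that a chlorine atom, para to a large group on this six-membered aromatic ring, is accommodated without a step beyond the scatter. Nothing shown here offers an explanation for this outcome.

As far as these compounds go, whether this holds for other groups at the same position, such as a methoxy group, a nitrile, a carboxylic acid or an amine, remains open. Also open is which of the several differences between compound 1 and compound 2 accounts for the numbers they show.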